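A few compounds are considered here, and "the series" means these few. Any claim that something is new, unique, unknown or untested is made for them only; others in the source may bear on it.

Of the compounds shown here, three built on one shared core have been tested in a functional assay on HGC-27 cells (Homo sapiens) for cytotoxicity, read by MTT assay, with a stated time of 72 h; a higher number here means a weaker inhibitor, a lower number a stronger inhibitor. Compound 1 `FC(F)(F)c1ccc(CSc2nc(Nc3ccccc3C(F)(F)F)c3ccccc3n2)cc1` reaches only the limit of the measurement, > 50000 nM. Compound 2 `Cc1ccccc1Nc1nc(SCc2ccc(C(F)(F)F)cc2)nc2ccccc12` gives 27500 nM in this assay. Compound 3 `FC(F)(F)c1ccc(CSc2nc(Nc3ccc(C(F)(F)F)cc3)c3ccccc3n2)cc1` gives 7560 nM in this assay, the lowest of the two numbers; its nearest neighbour is compound 2, with a 3.6-fold lower number from compound 2 to compound 3 (0.56 log units; beyond the scatter). The step of an at least 6.6-fold lower number from compound 1 to compound 3 (0.82 log units; beyond the scatter) is bounded by the limit of > 50000 nM in this assay, at which 1 of the 3 values shown sits. The step of an at least 1.8-fold lower number from compound 1 to compound 2 (0.25 log units; that floor lies within the scatter) has a floor that sits within the scatter.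

Compound 4 `COc1ccc(Nc2nc(SCc3ccc(C(F)(F)F)cc3)nc3ccccc23)cc1` differs from compound 3 in one place: methoxy in place of trifluoromethyl on an aromatic carbon. For the measured compounds named here, of the measured steps, only the one from compound 1 to compound 2 swaps one small group for another on the ring that hangs from the nitrogen, and its floor lies within the scatter; the two steps that lead to compound 3 exchange that whole ring, which is not the change here. Going by the values given here, no measured step trades a trifluoromethyl for a methoxy in the place described. The change in compound 4 is therefore expected to give a step of a 1.6-fold higher number from compound 3 to compound 4 (0.20 log units; within the scatter), within the scatter or modestly toward a higher number. Compound 4 is estimated at 12000 nM, with a range from 3500 nM to 45000 nM in this assay.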

Compound 4, half-maximal inhibitory concentration: 23500 nM
Compound 4: the middle estimate sits 2.0-fold (0.29 log units) below what was measured; low and high end bracket the measured number.
By their numbers in this assay, from the lowest: compound 3; then compounds 4 and 2 (each within the scatter of the next). At a limit, above all of these: compound 1.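

For the compounds shown here, this is the first step that keeps the position fixed and changes only the group on it: on an aromatic carbon para to a large group, methoxy in place of trifluoromethyl gives a 3.1-fold higher number from compound 3 to compound 4 (0.49 log units; beyond the scatter) in this assay, so the identity of the group matters here, not just where it sits. The change also removes the separation that compound 3 had from compound 2, since a 1.2-fold lower number from compound 2 to compound 4 (0.07 log units; within the scatter) leaves compound 2 and compound 4 with no order between them, even though their rings carry different groups at different places. Compound 4 still stands apart from compound 1, with an at least 2.1-fold lower number from compound 1 to compound 4 (0.32 log units; beyond the scatter), but that step is only a floor, as compound 1 is held at a limit rather than a number: the limit of > 50000 nM in this assay, at which 1 of the 4 values shown sits.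

From the compounds shown here alone, whether trifluoromethyl is the best group on this carbon stays open, as a single pair cannot rank it against a plain hydrogen, a chlorine, a nitrile, an amine or a carboxylic acid. The numbers also do not tell why the two groups differ, or whether the same exchange would do the same at the other trifluoromethyl that these compounds carry.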